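Swapping a hydroxyphenyl for a dichlorophenyl

This account rests on a few compounds, and the source may have more. Where it says the series, first, only, none or still open, it means among the compounds named here.

Values in a functional assay on SW-620 cells (Homo sapiens) for cytotoxicity, read by MTT assay, with a stated time of 72 h; a lower number here means a stronger inhibitor, a higher number a weaker inhibitor:
- Compound 1 `COc1cccc(/C=C2\CCC/C(=C\c3cccc(Br)c3)C2=O)c1OC`: 8800 nM
- Compound 2 `COc1cccc(/C=C2\CCC/C(=C\c3ccc(O)cc3)C2=O)c1OC`: > 20000 nM

Compound 2 stands at > 20000 nM, which is a limit and not a number. Compound 3 `COc1cccc(/C=C2\CCC/C(=C\c3cc(Cl)cc(Cl)c3)C2=O)c1OC` differs from it at one place: 3,5-dichlorophenyl in place of 4-hydroxyphenyl on a double-bonded chain carbon bound to a double-bonded ring carbon. Within the data shown here, the only measured step that bears on this is an at least 2.2-fold higher number from compound 1 to compound 2 (0.35 log units; beyond the scatter). That step replaced 3-bromophenyl with 4-hydroxyphenyl, and the new change removes the 4-hydroxyphenyl again in favour of a chlorine-bearing ring. A step of similar size towards a lower number is therefore expected in this assay. The expected step is an at least 2.5-fold lower number from compound 2 to compound 3 (0.39 log units; beyond the scatter). For compound 3 the estimated value is 8000 nM, with an expected range of 3000 nM to 20000 nM.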

Compound 3, half-maximal inhibitory concentration: 5500 nM
Compound 3: middle estimate off by 1.5-fold (0.16 log units), on the high side, and the stated range covers the measured number.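

In this assay, putting 3,5-dichlorophenyl in place of 4-hydroxyphenyl gives an at least 3.6-fold lower number from compound 2 to compound 3 (0.56 log units; beyond the scatter), so this position can carry a ring that does better than 4-hydroxyphenyl. Set against 3-bromophenyl, the same change gives a 1.6-fold lower number from compound 1 to compound 3 (0.20 log units; within the scatter), so the bromine-bearing and chlorine-bearing rings cannot be told apart here. Compound 2 sits at a limit and not a number: the limit of > 20000 nM in this assay, at which 1 of the 3 values shown sits.

As far as these compounds go, the step from 4-hydroxyphenyl swaps the group and its place on the ring together, so the effect of either alone stays open. Also open, from the compounds shown here alone, is how a ring carrying an amine or a carboxylic acid would compare.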